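The compounds below may be only part of what the source reports. "The series", "measured", "known", "first", "only" and "open" are said of these compounds alone.

In an ADME assay on A2780 cells (Homo sapiens) for inhibition, read by trypan blue exclusion, with a stated time of 72 h (on this read-out lower numbers stand for stronger inhibition of growth and higher numbers for weaker inhibition of growth), compound 1 (`COc1cccc(C(=O)/C=C/c2ccccc2)c1`) gives 8000 nM and compound 2 (`O=C(/C=C/c1ccccc1)c1ccccc1C(F)(F)F`) gives 5800 nM. Going by the values given here, compound 2 therefore stands within the scatter of compound 1, and no single-place step has been measured. Compound 3 (`COc1ccccc1C(=O)/C=C/c1ccccc1`) has methoxy in place of trifluoromethyl on an aromatic carbon, ortho to a large group: methoxy in place of trifluoromethyl on an aromatic carbon. Little change is expected in this assay because compound 1 with methoxy gives 8000 nM. The expected step is a 1.0-fold higher number from compound 2 to compound 3 (0.01 log units; within the scatter). For compound 3 the estimated value is 6000 nM, with an expected range from 2500 nM to 14000 nM.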

Compound 3, concentration for 50% growth inhibition: 7300 nM
Compound 3: the middle estimate sits 1.2-fold (0.09 log units) below what was measured; the range from low to high includes it.
By their numbers in this assay, from the lowest: compounds 2, 3 and 1 (each within the scatter of the next).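

In this assay, going by these compounds alone, the change to methoxy in place of trifluoromethyl on an aromatic carbon, ortho to a large group, gives a 1.3-fold higher number from compound 2 to compound 3 (0.10 log units; within the scatter) and is the first single-place step. At this position the two groups cannot be told apart on growth inhibition, even though they differ in heavy atoms and methoxy brings a hydrogen-bond acceptor. No measured evidence bears on this result. Open, from the compounds shown here alone, is whether an amine, a carboxylic acid or a longer chain at this position would move the number beyond the scatter.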